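Series notes: octyl replaced by 4-chlorophenoxy

This account rests on a few compounds, and the source may have more. Where it says the series, first, only, none or still open, it means among the compounds named here.

Measured so far, in an assay on microsomes from brain for inhibition of Fatty-acid amide hydrolase 1 (Rattus norvegicus), read by fluorescence and HPLC, with a stated time of 60 min; on this read-out lower numbers stand for stronger inhibition and higher numbers for weaker inhibition:
- compound 1 `CCCCCCCCc1ccc(OCC(=O)Cn2nnc(-c3ccc(C(=O)OC)cc3)n2)cc1`, compound 1 gives 29 nM
- compound 2 `CC(Oc1ccc(Oc2ccc(Cl)cc2)cc1)C(=O)Cn1nnc(-c2ccccc2)n1`, compound 2 gives 51 nM
- compound 3 `CCCCCCCCc1ccc(OC(C)C(=O)Cn2nnc(-c3ccc(C(=O)OC)cc3)n2)cc1`, compound 3 gives 25 nM

Going by the values given here, compound 3 gives the lowest of the three numbers, but the only single-point step among them, a 1.2-fold lower number from compound 1 to compound 3 (0.06 log units; within the scatter), is within the scatter, so compound 1 and compound 3 cannot be told apart. Compound 2 differs from compound 3 in two places at once, and its number is higher by more than the scatter; which of the two changes carries that is not resolved.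

Compound 4 `COC(=O)c1ccc(-c2nnn(CC(=O)C(C)Oc3ccc(Oc4ccc(Cl)cc4)cc3)n2)cc1` follows from compound 3 by 4-chlorophenoxy in place of octyl on an aromatic carbon. Among the compounds with values here, no measured step covers this change alone. Within the data shown here, compound 2 is the only compound carrying 4-chlorophenoxy, and its value 51 nM sits above compound 3, but it also lacks the methyl ester, so it bears on the step only loosely. Taking that hint as the sole guide, a modest move toward a higher number, or none beyond the scatter, is expected, estimated as a 1.6-fold higher number from compound 3 to compound 4 (0.20 log units; within the scatter). For compound 4 in this assay the estimate is 40 nM, with a range from 15 nM to 110 nM.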

Compound 4, half-maximal inhibitory concentration: 47 nM
Beside the measured number, compound 4's estimate is 1.2-fold (0.07 log units) below it, and the stated range covers the measured number.
By their numbers in this assay, from the lowest: compounds 3, 1, 4 and 2 (each within the scatter of the next, the first and the last beyond it).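

In this assay, putting 4-chlorophenoxy in place of octyl on this aromatic carbon, para to a large group, gives a 1.9-fold higher number from compound 3 to compound 4 (0.27 log units; within the scatter) and so does not separate an open chain from a group that carries an aromatic ring, at least with the methoxycarbonyl group in place. The second new step, a 1.1-fold lower number from compound 2 to compound 4 (0.04 log units; within the scatter) for methoxycarbonyl in place of hydrogen, shows that with 4-chlorophenoxy present this group also leaves the number within the scatter, and all three single-place steps among these compounds now lie within it. Nothing available explains why these changes leave the number within the scatter.

On these data alone, whether a shorter octyl-type chain such as butyl, a longer chain, or an amine on the same aromatic carbon would give a step beyond the scatter remains open. So does whether a carboxylic acid in place of the methoxycarbonyl group would do so, and whether the pattern seen in the four compounds would hold with that group on the core of compound 4.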